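Cytotoxicity of Three Biaryl Acids and a Nitro Analogue

The source may hold more compounds than are shown below. What is called first, only, known or untested is meant among the compounds shown, and "the series" means these compounds.

Compound 1 `CC(C)N(Cc1cccc(OCCCCCC(=O)O)c1)C(=O)c1ccc(-c2cccc(N(C)C)c2)cc1`: in an ADME assay on Raji cells (Homo sapiens) for cytotoxicity, read by CellTiter-Glo and resazurin assay, with a stated time of 72 h (on this read-out lower numbers stand for an effect already at smaller amounts and higher numbers for an effect only at larger amounts of compound), compound 1 gives > 26000 nM, which is a limit of the assay.
Compound 2 `CC(C)N(Cc1cccc(OCCCCCC(=O)O)c1)C(=O)c1ccc(-c2cccc(-c3ccccc3)c2)cc1`: in this assay compound 2 gives > 26000 nM, which is a limit of the assay.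
Compound 3 `CC(C)N(Cc1cccc(OCCCCCC(=O)O)c1)C(=O)c1ccc(-c2cccc(S(C)(=O)=O)c2)cc1`: in this assay compound 3 gives > 26000 nM, which is a limit of the assay.

Compound 3 therefore stands at a limit and not at a number, and it shares that position with every other measured compound, since (the limit of > 26000 nM in this assay, at which 3 of the 3 values shown sit). The compound to be measured next is compound 4 `CC(C)N(Cc1cccc(OCCCCCC(=O)O)c1)C(=O)c1ccc(-c2cccc([N+](=O)[O-])c2)cc1`, which differs from compound 3 in one place: nitro in place of methylsulfonyl on an aromatic carbon.

The measured steps that bear on this change are those from compound 1 and compound 2 to compound 3, namely a step that the two limits leave unreadable from compound 1 to compound 3 and a step that the two limits leave unreadable from compound 2 to compound 3; the remaining step, a step that the two limits leave unreadable from compound 1 to compound 2, is likewise unreadable. None of these steps gives a size or a direction, so there is no basis for expecting a step beyond the scatter in this assay for compound 4.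

The value of compound 4 in this assay is accordingly estimated at 40000 nM, with a range from 15000 nM to 100000 nM. The step that the limit leaves unreadable from compound 3 to compound 4 is expected to leave compound 4 at the same limit.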

Compound 4, half-maximal effective concentration: > 26000 nM
Compound 4: a limit, no number (the forecaster's own chance of this, stated with the estimate: 85%); the middle value is on the limit's open side.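

Compound 4 also stands at a limit in this assay and not at a number, so its steps from compound 1, compound 2 and compound 3 cannot be read in size or direction: the limit of > 26000 nM in this assay, at which 4 of the 4 values shown sit.

The compounds shown leave open how far any of the four lies from that limit, and whether exchanging these groups on the aromatic carbon changes the read-out at all.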